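A few compounds are considered here, and "the series" means these few. Any claim that something is new, unique, unknown or untested is made for them only; others in the source may bear on it.

Working notes on the series, read in a functional assay (trachea) with Cavia porcellus as the target; on this read-out lower numbers stand for stronger inhibition and higher numbers for weaker inhibition: compound 1 `Oc1nnc(-c2cccnc2)c2ccccc12` gives 10200 nM, compound 2 `CCCn1nc(-c2cccnc2)c2ccccc2c1=O` gives 3160 nM and compound 3 `CCn1nc(-n2ccnc2)c2ccccc2c1=O` gives 5370 nM. Compound 3 thus stands between the other two numbers, within the scatter of each. Compound 4 `CCn1nc(-c2cncnc2)c2ccccc2c1=O` keeps the shared core and the ethyl group of compound 3, with pyrimidin-5-yl in place of 1H-imidazol-1-yl on an aromatic carbon. Among the compounds with values here, no measured pair isolates this exchange. Compound 2 at 3160 nM and compound 3 at 5370 nM lie within the scatter of each other, so no change beyond the scatter is expected in this assay. The expected step of a 1.2-fold lower number from compound 3 to compound 4 (0.08 log units; within the scatter) stays within the scatter. For compound 4 the estimated value is 4500 nM, with an expected range of 1800 nM to 12000 nM.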

Compound 4, half-maximal inhibitory concentration: 9550 nM
Compound 4: middle estimate off by 2.1-fold (0.33 log units), on the low side, within the range that was stated.
By their numbers in this assay, from the lowest: compounds 2, 3, 4 and 1 (each within the scatter of the next, the first and the last beyond it).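

Within the data shown here, with the ethyl group and the shared core held fixed, the exchange of 1H-imidazol-1-yl for pyrimidin-5-yl on this aromatic carbon gives the first direct reading at this position: a 1.8-fold higher number from compound 3 to compound 4 (0.25 log units; within the scatter) in this assay. A five-membered aromatic ring and a six-membered one, each with 2 hetero atoms, therefore cannot be told apart here. No supporting data bear on this result.

From the compounds shown here alone, whether an amine or a carboxylic acid on this aromatic carbon would give a step beyond the scatter stays open. So does the outcome of a butyl chain in place of the ethyl group.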